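The compounds below may be only part of what the source reports. "The series", "measured", "known", "first", "only" and "open" are said of these compounds alone.

Compound 1 `Nc1ccccc1NC(=O)c1ccc(CSc2ccc(Br)cc2)cc1` gives 45.7% in a functional assay on A549 cells (Homo sapiens) for inhibition, read by CCK-8 assay, with a stated time of 72 h, tested at 8 uM (a lower number here means less inhibition of growth, a higher number more inhibition of growth at the concentration tested), and stands as the lower of the two numbers in hand; compound 2 `Nc1ccccc1NC(=O)/C=C/c1ccc(CSc2cccc(F)c2)cc1` gives 56.6% in this assay, a gap beyond the usual scatter. Compound 3 `CC(C)(C)c1ccc(SCc2ccc(C(=O)Nc3ccccc3N)cc2)cc1` differs from compound 1 by tert-butyl in place of bromo on an aromatic carbon. Within the data shown here, no measured pair shows this exchange, so its size is unknown; in this assay a step within the scatter, in either direction and tilted only slightly upward, is expected. Compound 3 is expected to give about 48% in this assay, between 32% and 64%, an expected step of a number 2.3 percentage points higher from compound 1 to compound 3 (within the scatter).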

Compound 3, percent growth inhibition at one concentration: 67%
The estimate for compound 3 lay 19 percentage points below the measured number; measured number outside the range, above it.
By their numbers in this assay, from the lowest: compound 1; then compound 2; then compound 3.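

In this assay, tert-butyl in place of bromo on an aromatic carbon, para to a large group, gives a number 21.3 percentage points higher from compound 1 to compound 3 (beyond the scatter) on an otherwise unchanged core. Among these compounds, this is the only single-place step in hand, and it shows that growth inhibition at the concentration tested depends on what this position carries. The data in hand offer no explanation for the step.

Among the compounds shown here, with only two groups compared here, it remains open how a methoxy group or an amine at this position would read. From the compounds shown here alone, whether the same exchange would hold on the core of compound 2 also remains open.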